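The source may hold more compounds than are shown below. What is called first, only, known or untested is meant among the compounds shown, and "the series" means these compounds.

Measured in a functional assay on Bel-7402 cells (Homo sapiens) for inhibition, read by MTT assay, with a stated time of 24 h, tested at 0.1 ug/mL; on this read-out lower numbers stand for less inhibition of growth and higher numbers for more inhibition of growth at the one concentration tested:
Compound 1 `O=C(CCCCC(S)CCS)Nc1ccc(Cl)cc1`: 1.06%
Compound 2 `O=C(CCCCC(S)CCS)Nc1ccc(OC(F)(F)F)cc1`: "not active" (no number reported)
Compound 3 `COc1ccc(NC(=O)CCCCC(S)CCS)cc1`: 5.35%

Compound 3, at 5.35%, stands within the scatter of compound 1, at 1.06%. Compound 2 has no number to compare, being reported as "not active" (no number reported).

The next compound is compound 4 `O=C(CCCCC(S)CCS)Nc1ccc([N+](=O)[O-])cc1`, which departs from compound 3 by one exchange: nitro in place of methoxy on an aromatic carbon. Nitro takes the place of methoxy, para to a large group.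

Among the measured compounds shown here, only one measured step bears on this place: a number 4.3 percentage points higher from compound 1 to compound 3 (within the scatter), where methoxy replaces chloro. For the measured compounds named here, no measured compound yet carries nitro, so that step is only an indirect guide. Since it stays within the scatter, no step beyond the scatter is expected in this assay. The expected change is a number 1.4 percentage points lower from compound 3 to compound 4 (within the scatter), a shift with no clear direction.

Compound 4 is estimated at 4%, with an expected range from 0% to 12%.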

Compound 4, percent growth inhibition at one concentration: 1.88%
The estimate for compound 4 lay 2.1 percentage points above the measured number; the measured number falls inside the stated range.
By their numbers in this assay, from the lowest: compounds 1, 4 and 3 (each within the scatter of the next).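

In this assay the exchange of methoxy for nitro gives a number 3.5 percentage points lower from compound 3 to compound 4 (within the scatter), and the exchange of chloro for nitro gives a number 0.8 percentage points higher from compound 1 to compound 4 (within the scatter). Chloro, methoxy and nitro on this aromatic carbon therefore cannot be told apart on this read-out, and nitro, though it has more heavy atoms and hydrogen-bond acceptors than methoxy, brings no step beyond the scatter; steps involving compound 2 cannot be read, as it has no number. No measurement given here explains this result.

The compounds shown leave open whether any group at this place can produce a step beyond the scatter, for instance an amine or a carboxylic acid. They also leave open whether a longer chain in the shared core would change the picture.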